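Chain extension from compound 3 to compound 4

This account rests on a few compounds, and the source may have more. Where it says the series, first, only, none or still open, it means among the compounds named here.

In a functional assay on A549 cells (Homo sapiens) for antiproliferative activity, read by MTT assay, with a stated time of 48 h (a lower number here means a stronger inhibitor, a higher number a weaker inhibitor), compound 1 `Cn1cc(C2=C(c3nn(CCCN4CCCCC4)c4ncccc34)C(=O)N(c3cccc4ccccc34)C2=O)c2ccccc21` gives 2820 nM and compound 2 `Cn1cc(C2=C(c3nn(CCCn4ccnc4)c4ncccc34)C(=O)N(c3ccccc3)C2=O)c2ccccc21` gives 1560 nM. Compound 3 `Cn1cc(C2=C(c3nn(CCCn4ccnc4)c4ncccc34)C(=O)NC2=O)c2ccccc21` gives > 100000 nM, which is a limit of the assay and not a number. Compound 3 therefore stands at the limit of > 100000 nM in this assay, at which 1 of the 3 values shown sits.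

Among the compounds with values here, the one measured step is an at least 64-fold higher number from compound 2 to compound 3 (1.80 log units; beyond the scatter), with hydrogen in place of phenyl on an amide-type nitrogen in a ring. Compound 4 `Cn1cc(C2=C(c3nn(CCCCn4ccnc4)c4ncccc34)C(=O)NC2=O)c2ccccc21` keeps that hydrogen and differs from compound 3 in the side chain: (1H-imidazol-1-yl)methyl in place of 1H-imidazol-1-yl on a saturated chain carbon, three bonds along the chain from an aromatic nitrogen. In other words, 3-(1H-imidazol-1-yl)propyl gives way to 4-(1H-imidazol-1-yl)butyl.

Within the data shown here, no measured step changes this chain, so the size of the change has no direct precedent. The large step to compound 3 bears on it only indirectly, since it sets the level from which compound 4 starts. In this assay the expectation is therefore no step beyond the scatter, in either direction, with a good chance that compound 4 also reaches the limit.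

The expected step is an at least 1.2-fold lower number from compound 3 to compound 4 (0.09 log units; that floor lies within the scatter).

For compound 4 the estimated value is 80000 nM, with an expected range of 25000 nM to 150000 nM.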

Compound 4, half-maximal inhibitory concentration: 2380 nM
Beside the measured number, compound 4's estimate is 34-fold (1.53 log units) above it, outside the stated range (below it).
By their numbers in this assay, from the lowest: compounds 2, 4 and 1 (each within the scatter of the next). At a limit, above all of these: compound 3.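

In this assay, the side chain proves to be a sensitive position even with the amide hydrogen kept: 4-(1H-imidazol-1-yl)butyl in place of 3-(1H-imidazol-1-yl)propyl gives an at least 42-fold lower number from compound 3 to compound 4 (1.62 log units; beyond the scatter). The earlier step, an at least 64-fold higher number from compound 2 to compound 3 (1.80 log units; beyond the scatter), had tied the loss of a measurable value to the hydrogen in place of phenyl, but compound 4 shows that this hydrogen does not by itself rule out a measurable value in this series, so the effect of that hydrogen depends on the chain it is paired with. Both steps have only a lower bound, because compound 3 stands at a limit and not at a number: the limit of > 100000 nM in this assay, at which 1 of the 4 values shown sits.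

The compounds shown leave open whether the dependence on chain length continues in either direction, as a shorter 2-(1H-imidazol-1-yl)ethyl or a longer 5-(1H-imidazol-1-yl)pentyl chain would test. They also leave open whether 4-(1H-imidazol-1-yl)butyl adds anything when phenyl sits on the amide-type nitrogen, and whether the imidazole on this chain can be replaced by an amine such as morpholine.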